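The compounds below may be only part of what the source reports. "The series", "measured", "known", "first", "only" and "open" are said of these compounds alone.

In a functional assay on KB cells (Homo sapiens) for inhibition, with a stated time of 72 h (a lower number here means a stronger inhibitor, a higher number a weaker inhibitor), compound 1 (`COc1ccc(S(=O)(=O)N2CCc3cccc(-c4ccco4)c32)cc1`) gives 82 nM while compound 2 (`COc1ccc(S(=O)(=O)N2CCc3cccc(-c4ccc(F)c(F)c4)c32)cc1`) gives 45 nM and compound 3 (`COc1ccc(S(=O)(=O)N2CCc3cccc(-c4ccc(F)cc4)c32)cc1`) gives 86 nM so compound 3 stands within the scatter of both others. Compound 4 (`COc1ccc(S(=O)(=O)N2CCc3cccc(-c4ccncc4)c32)cc1`) has pyridin-4-yl in place of 4-fluorophenyl on an aromatic carbon. The measured steps bearing on this are a 1.0-fold higher number from compound 1 to compound 3 (0.02 log units; within the scatter) and a 1.8-fold lower number from compound 1 to compound 2 (0.26 log units; within the scatter) at that same carbon and also a 1.9-fold higher number from compound 2 to compound 3 (0.28 log units; within the scatter) on the fluoro, each within the scatter. Among the compounds with values here, no measured compound carries pyridin-4-yl, so the direction stays open. An expected step of a 1.2-fold higher number from compound 3 to compound 4 (0.07 log units; within the scatter) in this assay stays inside the scatter. The estimate for compound 4 is 100 nM with an expected range from 40 nM to 300 nM for this measurement.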

Compound 4, half-maximal inhibitory concentration: 96 nM
Beside the measured number, compound 4's estimate is 1.0-fold (0.02 log units) above it, within the range that was stated.
By their numbers in this assay, from the lowest: compounds 2, 1, 3 and 4 (each within the scatter of the next, the first and the last beyond it).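

In this assay pyridin-4-yl, with its ring nitrogen, reads much like the groups it replaces at this aromatic carbon: a 1.1-fold higher number from compound 3 to compound 4 (0.05 log units; within the scatter) and a 1.2-fold higher number from compound 1 to compound 4 (0.07 log units; within the scatter) both stay within the scatter. Within the data shown here, only the comparison with 3,4-difluorophenyl passes the scatter, and only modestly, with a 2.1-fold higher number from compound 2 to compound 4 (0.33 log units; beyond the scatter) as the one step of this kind. No evidence is available to explain these steps.

As far as these compounds go, how a piperidin-1-yl group or a carboxylic acid at this carbon would read stays open.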